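A few compounds are considered here, and "the series" means these few. Any claim that something is new, unique, unknown or untested is made for them only; others in the source may bear on it.

Measured so far in a functional assay on HepG2 cells (Homo sapiens) for cytotoxicity, read by MTT assay, with a stated time of 24 h; on this read-out lower numbers stand for stronger inhibition and higher numbers for weaker inhibition:
- compound 1 `CN1C/C(=C\c2ccc(C(F)(F)F)cc2)C(=O)/C(=C/c2ccccc2F)C1`: 4140 nM
- compound 2 `CN1C/C(=C\c2cccc([N+](=O)[O-])c2)C(=O)/C(=C/c2ccccc2F)C1`: 1080 nM

Of these two numbers, compound 2 has the lower, at 1080 nM. Compound 1 stands at 4140 nM, and the gap between them lies beyond the usual scatter of repeated measurements.

Next in the series is compound 3 `CN1C/C(=C\c2cccc([N+](=O)[O-])c2)C(=O)/C(=C/c2ccc(Cl)cc2Cl)C1`, which still has to be measured in this assay. The structural change from compound 2 is 2,4-dichlorophenyl in place of 2-fluorophenyl on a double-bonded chain carbon bound to a double-bonded ring carbon.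

For the measured compounds named here, no measured pair shows a change at this place, so the data give no direct guide to its size or direction. The working expectation is therefore no step beyond the scatter, and compound 2 at 1080 nM serves as the anchor. The estimated step is a 1.1-fold lower number from compound 2 to compound 3 (0.03 log units; within the scatter), with considerable uncertainty in either direction. For compound 3 the expected value is 1000 nM, with an estimated range of 350 nM to 3000 nM.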

Compound 3, half-maximal inhibitory concentration: 4800 nM
For compound 3 the middle estimate is 4.8-fold (0.68 log units) below the measured one; measured number above the stated range.
By their numbers in this assay, from the lowest: compound 2; then compounds 1 and 3 (each within the scatter of the next).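

In this assay, the aryl group on a double-bonded chain carbon bound to a double-bonded ring carbon proves able to shift the read-out: a 4.4-fold higher number from compound 2 to compound 3 (0.65 log units; beyond the scatter), a step beyond the scatter and the first change seen at this place. With the rest of the structure held constant, 2-fluorophenyl gives the stronger inhibition of these two groups, although this rests on a single pair and holds only for the background shared by compound 2 and compound 3. No available measurement bears on why this step arises.

The change removes the fluorine and adds two chlorines in one move, so this pair cannot show whether the step comes from losing the fluorine, from gaining either chlorine, or from both together. Also open, on these data alone, are how an unsubstituted phenyl, a 4-chlorophenyl or a phenyl carrying an amine or a carboxylic acid would read at this place, and whether a step of similar size would appear with the 4-(trifluoromethyl)phenyl group of compound 1 elsewhere in the structure.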